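From acetyl to methoxy on the shared core

The compounds below may be only part of what the source reports. "The series", "measured", "known", "first", "only" and "open" are said of these compounds alone.

In a functional assay on A549 cells (Homo sapiens) for inhibition, read by MTT assay, with a stated time of 24 h (a lower number here means a stronger inhibitor, a higher number a weaker inhibitor), compound 1 `O=[N+]([O-])c1ccc(/C=C/[C@@H]2CCCCN2)cc1` gives 3.27 ug/mL and compound 2 `CC(=O)c1ccc(/C=C/[C@@H]2CCCCN2)cc1` gives 3.69 ug/mL. Compound 2 therefore stands level with compound 1, as the two values lie within the scatter of each other.

Compound 3 `COc1ccc(/C=C/[C@@H]2CCCCN2)cc1` keeps the core of compound 2 and carries methoxy in place of acetyl on an aromatic carbon. The exchange sits on a six-membered aromatic ring of carbon only, para to a group of 8 heavy atoms.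

Among the measured compounds shown here, only one measured step bears on this change: a 1.1-fold higher number from compound 1 to compound 2 (0.05 log units; within the scatter). It exchanges a group at the same place and stays within the scatter. For the measured compounds named here, it is weak evidence, since no measured compound carries methoxy and a single step cannot set a direction. Nothing beyond the scatter is therefore expected in this assay.

The expected step is a 1.0-fold higher number from compound 2 to compound 3 (0.00 log units; within the scatter), which would leave the two compounds level. For compound 3 the estimate is 3.7 ug/mL, with an expected range of 1.8 ug/mL to 7.5 ug/mL.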

Compound 3, half-maximal inhibitory concentration: 4.33 ug/mL
Beside the measured number, compound 3's estimate is 1.2-fold (0.07 log units) below it; measured number inside the range.
By their numbers in this assay, from the lowest: compounds 1, 2 and 3 (each within the scatter of the next).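

In this assay, the place on the six-membered aromatic ring of carbon only, para to a group of 8 heavy atoms, now has a third group, methoxy. Its exchange for acetyl gives a 1.2-fold higher number from compound 2 to compound 3 (0.07 log units; within the scatter), and its exchange for nitro gives a 1.3-fold higher number from compound 1 to compound 3 (0.12 log units; within the scatter). The earlier compounds shown here offered a single exchange at this place, whereas nitro, acetyl and methoxy now stand level in all three pairings, and the move from acetyl to methoxy, with one heavy atom fewer and no double bond outside aromatic rings, leaves the number within the scatter. No measurement accompanies these cell numbers that could account for the level readings.

From the compounds shown here alone, whether an amine, a carboxylic acid or a longer chain such as butoxy at this same place would stay level with these three, or would move the number beyond the scatter, remains open. Also open, going by these compounds, is how the number responds to a change elsewhere on the shared core, such as a methyl group on the ring nitrogen, which none of the three compounds carries.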